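The source may hold more compounds than are shown below. What is called first, only, known or untested is meant among the compounds shown, and "the series" means these compounds.

Compound 1 `CN1CCN(CCCCCn2c3c(c4ccccc42)C(=O)c2c[n+]([O-])c4ccccc4c2C3=O)CC1` gives 870 nM in a functional assay on A549 cells (Homo sapiens) for cytotoxicity, read by MTT assay, with a stated time of 72 h; on this read-out higher numbers stand for weaker inhibition and lower numbers for stronger inhibition.
Compound 2 `CCCCN1CCN(CCCCn2c3c(c4ccccc42)C(=O)c2c[n+]([O-])c4ccccc4c2C3=O)CC1` gives 550 nM in this assay.
Compound 3 `O=C1c2c[n+]([O-])c3ccccc3c2C(=O)c2c1c1ccccc1n2CCCN1CCC(O)CC1` gives 350 nM in this assay.

Compound 3 has the lowest number of the three. Its separation from compound 1 is a 2.5-fold lower number from compound 1 to compound 3 (0.40 log units; beyond the scatter), a modest step beyond the scatter, while its separation from compound 2 is a 1.6-fold lower number from compound 2 to compound 3 (0.20 log units; within the scatter), which lies within the scatter, so compound 3 cannot be set apart from compound 2 on these numbers.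

Compound 4 `O=C1c2c[n+]([O-])c3ccccc3c2C(=O)c2c1c1ccccc1n2CCCCn1ccnc1` is not yet measured. The change from compound 3 is (1H-imidazol-1-yl)methyl in place of 4-hydroxypiperidin-1-yl on a saturated chain carbon, three bonds along the chain from an aromatic nitrogen.

Going by the values given here, the steps that bear on this change are those in which the chain end was altered: a 1.6-fold lower number from compound 1 to compound 2 (0.20 log units; within the scatter) and a 1.6-fold lower number from compound 2 to compound 3 (0.20 log units; within the scatter) stayed within the scatter, and a 2.5-fold lower number from compound 1 to compound 3 (0.40 log units; beyond the scatter) was modest. Every one of these replaced one saturated nitrogen ring with another, and none introduced a five-membered aromatic ring at the chain end, so the measured steps show that altering this chain end has so far moved the number little, but give no direct guide for the entering group. The expectation in this assay is therefore a step of no more than the scatter, with a slight lean toward a higher number for compound 4.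

Compound 4 is expected to give about 500 nM, with a range from 200 nM to 1300 nM. The estimated step is a 1.4-fold higher number from compound 3 to compound 4 (0.15 log units; within the scatter).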

Compound 4, half-maximal inhibitory concentration: 170 nM
Estimate against measurement, compound 4: 2.9-fold (0.47 log units) above; measured number outside the range, below it.
By their numbers in this assay, from the lowest: compound 4; then compounds 3, 2 and 1 (each within the scatter of the next, the first and the last beyond it).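

In this assay, the chain end proves able to move the number beyond what the swaps among saturated nitrogen rings suggested: replacing 4-hydroxypiperidin-1-yl with (1H-imidazol-1-yl)methyl on the saturated chain carbon, three bonds along the chain from an aromatic nitrogen, gives a 2.1-fold lower number from compound 3 to compound 4 (0.31 log units; beyond the scatter). Against the piperazine-ended chains, the entering ring gives a 3.2-fold lower number from compound 2 to compound 4 (0.51 log units; beyond the scatter) and a 5.1-fold lower number from compound 1 to compound 4 (0.71 log units; beyond the scatter), so compound 4 holds the lowest number of the four, with each of its steps beyond the scatter, and a five-membered aromatic ring without a hydrogen-bond donor is compatible with the best cytotoxicity seen here. Nothing in hand accounts for this gain.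

The comparison also joins two changes, since 3-(4-hydroxypiperidin-1-yl)propyl gives way to 4-(1H-imidazol-1-yl)butyl, and the compounds shown do not separate the contribution of the imidazole ring from that of the longer chain; a 3-(1H-imidazol-1-yl)propyl chain on the same core would do so. On these data alone, whether the imidazole nitrogen pattern itself matters also remains open, and a 1H-pyrazol-1-yl or 1H-1,2,4-triazol-1-yl chain end would test it.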